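Hydroxypropyl ether of a protected tetrahydropyran diol

A few compounds are considered here, and "the series" means these few. Any claim that something is new, unique, unknown or untested is made for them only; others in the source may bear on it.

Measured compounds:
- compound 1: `C=CCOC[C@H]1OCCC[C@H]1O[Si](C)(C)C(C)(C)C` gives 88000 nM
- compound 2: `COC(=O)/C=C/OC[C@H]1OCCC[C@H]1O[Si](C)(C)C(C)(C)C` gives 36000 nM

Compound 1 and compound 2 were measured in a functional assay on WiDr cells (Homo sapiens) for antiproliferative activity, read by sulforhodamine B assay, with a stated time of 48 h; a lower number here means a stronger inhibitor of growth, a higher number a weaker inhibitor of growth. Among the measured compounds shown here, compound 2 has the lowest number of the two; its nearest neighbour is compound 1, and the one step between them, a 2.4-fold lower number from compound 1 to compound 2 (0.39 log units; beyond the scatter), was modest but beyond the scatter.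

Compound 3, `CC(C)(C)[Si](C)(C)O[C@@H]1CCCO[C@@H]1COCCCO`, has not yet been measured. It differs from compound 2 in one place: 3-hydroxypropyl in place of 2-(methoxycarbonyl)ethenyl on an oxygen on a saturated carbon. For the measured compounds named here, the only step that bears on this change is a 2.4-fold lower number from compound 1 to compound 2 (0.39 log units; beyond the scatter), where bringing in the 2-(methoxycarbonyl)ethenyl group lowered the number modestly. Compound 3 removes that same group again and puts a 3-hydroxypropyl group in its place, so the gain seen in that step is expected to be given back, and the number is expected to rise to roughly where compound 1 stands, or somewhat beyond it. The expected step is a 2.5-fold higher number from compound 2 to compound 3 (0.40 log units; beyond the scatter), upward. For compound 3 the estimate is 90000 nM, with a likely range from 40000 nM to 200000 nM.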

Compound 3, concentration for 50% growth inhibition: > 100000 nM
Compound 3: no number, only a limit (the forecaster's own chance of this, stated with the estimate: 20%); middle value at least 1.1-fold (0.04 log units) from the limit.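

Compound 3 gives no number in this assay, only a limit of the assay: the limit of > 100000 nM in this assay, at which 1 of the 3 values shown sits.

Even so, putting 3-hydroxypropyl in place of 2-(methoxycarbonyl)ethenyl on this oxygen gives an at least 2.7-fold higher number from compound 2 to compound 3 (0.44 log units; beyond the scatter), so a second replacement at this position now separates from compound 2, and the earlier comparison with compound 1 no longer stands alone. Against the allyl compound the reading is an at least 1.1-fold higher number from compound 1 to compound 3 (0.05 log units; that floor lies within the scatter), so the floor of this step does not separate compound 3 from compound 1, and the two cannot be placed in order, even though the end of the chain now carries a hydroxyl group.

On these data alone, how far compound 3 lies beyond its limit stays unknown, so its step from compound 2 has a floor but no upper end. As far as these compounds go, it also stays open whether the lower number of compound 2 depends on the methoxycarbonyl part or on the double bond, and whether a carboxylic acid, an amine or a longer chain on this oxygen would lower the number further.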